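Stereodefined isomer of the thioester core assayed for nitrite

This account rests on a few compounds, and the source may have more. Where it says the series, first, only, none or still open, it means among the compounds named here.

The series rests on a shared core, drawn without configuration in compound 2 `O=C(SC12CCC(O)C1C(=O)NC2=O)c1ccc(O)cc1` and with full configuration in compound 1 `O=C(S[C@@]12CC[C@H](O)[C@@H]1C(=O)NC2=O)c1ccc(O)cc1` and compound 3 `O=C(S[C@@]12CC[C@@H](O)[C@@H]1C(=O)NC2=O)c1ccc(O)cc1`. In a functional assay on RAW264.7 cells (Mus musculus) for inhibition, read by Griess assay, with a stated time of 24 h (on this read-out lower numbers stand for stronger inhibition and higher numbers for weaker inhibition), compound 2 gives 225000 nM, the highest of the three numbers; compound 1 gives 71800 nM and compound 3 gives 127000 nM. Within the data shown here, the step of a 3.1-fold higher number from compound 1 to compound 2 (0.50 log units; beyond the scatter) is beyond the scatter, and the fact that one of compounds 1 and 2 is drawn with a defined configuration and the other without, at the place where they differ is the only feature separating the pair. The step of a 1.8-fold higher number from compound 1 to compound 3 (0.25 log units; within the scatter) is within the scatter, the pair differing only as stated in the fact that compounds 1 and 3 differ only in the configuration as drawn. The step of a 1.8-fold lower number from compound 2 to compound 3 (0.25 log units; within the scatter) is likewise within the scatter, with the fact that one of compounds 2 and 3 is drawn with a defined configuration and the other without, at the place where they differ the sole difference.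

Compound 4 `O=C(S[C@]12CC[C@H](O)[C@H]1C(=O)NC2=O)c1ccc(O)cc1` differs from compound 2 as follows: the two compounds have the same atoms and bonds; at least one stereo element is drawn with a configuration in one of them and without one in the other: 3 of 3 stereo elements differ; a stereocentre at a saturated ring carbon is drawn without a configuration in compound 2 and R in compound 4; a stereocentre at a saturated ring carbon is drawn without a configuration in compound 2 and S in compound 4; a stereocentre at a saturated ring carbon is drawn without a configuration in compound 2 and S in compound 4. The relevant steps are those that move from the undefined drawing to a defined one, namely a 3.1-fold higher number from compound 1 to compound 2 (0.50 log units; beyond the scatter) and a 1.8-fold lower number from compound 2 to compound 3 (0.25 log units; within the scatter); one is modest and beyond the scatter, the other within it. The author therefore expects at most a modest fall in the number in this assay, and possibly none beyond the scatter. Compound 4 is estimated at 150000 nM, within a range from 60000 nM to 400000 nM, corresponding to the expected step of a 1.5-fold lower number from compound 2 to compound 4 (0.18 log units; within the scatter).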

Compound 4, half-maximal inhibitory concentration: 141000 nM
Compound 4: the middle estimate sits 1.1-fold (0.03 log units) above what was measured; the range from low to high includes it.
By their numbers in this assay, from the lowest: compounds 1, 3, 4 and 2 (each within the scatter of the next, the first and the last beyond it).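

Compound 4, the mirror image of compound 3, shows that inverting all three stereocentres leaves the number in this assay within the scatter (a 1.1-fold higher number from compound 3 to compound 4 (0.05 log units; within the scatter)). Compound 4 also stays within the scatter of compound 1, from which it differs at two of the three stereocentres (a 2.0-fold higher number from compound 1 to compound 4 (0.29 log units; within the scatter)), and of the undefined drawing (a 1.6-fold lower number from compound 2 to compound 4 (0.20 log units; within the scatter)). Across these four compounds, a change of configuration or its definition therefore separates only one pair beyond the scatter, compound 1 and compound 2 (a 3.1-fold higher number from compound 1 to compound 2 (0.50 log units; beyond the scatter)), and the full inversion now adds a mirror-image pair that this read-out does not distinguish.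

All four compounds share the same atoms and bonds, so they leave open how the read-out would respond to a change in the groups themselves, such as an amine or a carboxylic acid in place of a hydroxyl group, or an oxygen ester in place of the thioester. They also leave open whether the gap between compound 1 and compound 2 would persist in such analogues.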